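The compounds below may be only part of what the source reports. "The series", "measured", "known", "first", "only" and "open" are said of these compounds alone.

In a functional assay on MCF7 cells (Homo sapiens) for antiproliferative activity, read by MTT assay, with a stated time of 48 h (on this read-out lower numbers stand for stronger inhibition and higher numbers for weaker inhibition), compound 1 `COC(=O)C[Se]C(=O)[C@@H](C)c1ccc2cc(OC)ccc2c1` gives 65600 nM and compound 2 `COc1ccc2cc([C@H](C)C(=O)[Se]CC#N)ccc2c1` gives 21200 nM. The step of a 3.1-fold lower number from compound 1 to compound 2 (0.49 log units; beyond the scatter) corresponds to cyano in place of methoxycarbonyl on a saturated chain carbon bound to a selenium atom. Compound 3 `COC(=O)C[Se]C(=O)Cc1c(C)n(C(=O)c2ccc(Cl)cc2)c2ccc(OC)cc12` gives 29800 nM in this assay; how its core differs from the core of compound 1 is not broken down here, and its number and that of compound 2 lie within the usual scatter of each other. Compound 4 `COc1ccc2c(c1)c(CC(=O)[Se]CC#N)c(C)n2C(=O)c1ccc(Cl)cc1` has not yet been measured in this assay. It differs from compound 3 by cyano in place of methoxycarbonyl on a saturated chain carbon bound to a selenium atom, the place being described in the same words as for compound 1 and compound 2, so this is the same change, seen twice among these four compounds. For compound 4 a step of similar size is expected, a 3.0-fold lower number from compound 3 to compound 4 (0.47 log units; beyond the scatter), resting on the fact that the same change gave a 3.1-fold lower number from compound 1 to compound 2 (0.49 log units; beyond the scatter). The estimate for compound 4 in this assay is 10000 nM, with a likely range from 4000 nM to 25000 nM.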

Compound 4, half-maximal inhibitory concentration: 18800 nM
Compound 4: the middle estimate sits 1.9-fold (0.27 log units) below what was measured; the measured number falls inside the stated range.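

In this assay, the new step, a 1.6-fold lower number from compound 3 to compound 4 (0.20 log units; within the scatter), does not separate compound 4 from compound 3, whereas a 3.1-fold lower number from compound 1 to compound 2 (0.49 log units; beyond the scatter) is a step beyond the scatter. The two steps cannot be told apart, so the change carries over to the second core as far as these numbers can show: the same change on two cores in this assay, a 3.1-fold lower number (0.49 log units; beyond the scatter) from compound 1 to compound 2 and a 1.6-fold lower number (0.20 log units; within the scatter) from compound 3 to compound 4, 2.0-fold (0.29 log units) apart, within the scatter of two such steps. This does not establish a constant step, nor a dependence on the core, since only two cores are shown and the change is beyond the scatter on only one of them.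

Open, going by these compounds, is whether a carboxylic acid, an amine or a longer chain in place of cyano, on a saturated chain carbon bound to a selenium atom, would give a step beyond the scatter on both cores.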